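Compound 4: cycloheptyl in place of pyridin-4-yl

The compounds below may be only part of what the source reports. "The series", "measured", "known", "first", "only" and "open" are said of these compounds alone.

Three amides sharing one core have entered an ADME assay on Vero cells (Chlorocebus sabaeus) for cytotoxicity, read by resazurin assay (on this read-out lower numbers stand for stronger inhibition and higher numbers for weaker inhibition), and only one of them has a result. Compound 1 (`Cc1cc(C)c2cc(C(=O)NC3CCCCC3)[nH]c2c1`) gives > 200000 nM, which is a limit of the assay and not a number. Compound 2 (`Cc1cc(C)c2cc(C(=O)Nc3ccncc3)[nH]c2c1`) has no number to stand on, its entry reading "not determined" (no result reported). Compound 3 (`Cc1cc(C)c2cc(C(=O)NC3CCCN(C)CC3)[nH]c2c1`) has the same standing, with an entry of "not determined" (no result reported).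

Still unmeasured is compound 4 (`Cc1cc(C)c2cc(C(=O)NC3CCCCCC3)[nH]c2c1`). The structural change cycloheptyl in place of pyridin-4-yl on an amide-type nitrogen places cycloheptyl in place of pyridin-4-yl on an amide-type nitrogen. Among the compounds with values here, no measured step shows what such a change does, and the missing value for compound 2 means that no size can be read from that side. Within the data shown here, the only anchor is compound 1, with the limit of > 200000 nM in this assay, at which 1 of the 3 values shown sits. In this assay, a strong move towards lower numbers is therefore not expected, and the result is expected to lie close to that limit. Compound 4 is estimated at 170000 nM, with an expected range from 70000 nM to 250000 nM.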

Compound 4, half-maximal inhibitory concentration: > 200000 nM
Compound 4 ended at the assay's limit; the forecaster's own chance of this, stated with the estimate: 60%; middle value at least 1.1-fold (0.07 log units) from the limit.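

No new step can be read: compound 1 and compound 4 both stand at a limit of this assay, not at a number, so the change from cyclohexyl to cycloheptyl has no readable size. The compounds shown leave open whether any amide on the shared core gives a readable value in this assay.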